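Cytotoxicity tolerance across a chain-substituent change

This account rests on a few compounds, and the source may have more. Where it says the series, first, only, none or still open, it means among the compounds named here.

In an ADME assay on HEp-2 cells (Homo sapiens) for cytotoxicity, with a stated time of 4 days (a lower number here means that less compound is tolerated, a higher number that more compound is tolerated), compound 1 `CS(=O)(=O)CCCn1c(Cn2cc(S(C)(=O)=O)c3ccccc32)nc2cc(Cl)ccc21` gives > 100000 nM, which is a limit of the assay and not a number. Compound 2 `CS(=O)(=O)CCCn1c(Cn2nc(S(C)(=O)=O)c3ccncc32)nc2cc(Cl)ccc21` gives > 100000 nM in this assay, again a limit rather than a number. Among the compounds with values here, compound 2 thus stands at the limit itself, as does the only other value shown, summarised by the limit of > 100000 nM in this assay, at which 2 of the 2 values shown sit. Within the data shown here, no step between measured compounds can be read from these two limits.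

Compound 3 `CS(=O)(=O)c1nn(Cc2nc3cc(Cl)ccc3n2CCCCO)c2cnccc12` is not yet measured in this assay. It differs from compound 2 as follows: hydroxymethyl in place of methylsulfonyl on a saturated chain carbon, three bonds along the chain from an aromatic nitrogen. Nothing measured within this series speaks to that change. Given that compound 2 sits at > 100000 nM as a limit, the expected step is a number no higher from compound 2 to compound 3 (the limit leaves the size open), none beyond the scatter. Compound 3 is expected to give about 100000 nM in this assay, within 40000 nM to 300000 nM, most probably reported once more as a limit.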

Compound 3, half-maximal cytotoxic concentration: > 100000 nM
Compound 3 was reported as a limit; the forecaster's own chance of this, stated with the estimate: 80%; the middle value sits exactly at the limit.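

In this assay compound 3 gives > 100000 nM, a limit and not a number. Compound 2 also stands at a limit, so no step can be read between compound 2 and compound 3. The compounds shown leave open at what concentration any of them becomes cytotoxic, and whether 4-hydroxybutyl in place of 3-(methylsulfonyl)propyl alters tolerance at all: the limit of > 100000 nM in this assay, at which 3 of the 3 values shown sit.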